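Replacing pyrrolidin-1-yl with ethyl(methyl)amino on the carbonyl

The compounds below may be only part of what the source reports. "The series", "measured", "known", "first", "only" and "open" are said of these compounds alone.

In an ADME assay (liver) for metabolic stability, with Liver microsome (Rattus norvegicus) as the target, using microsomes (on this read-out lower numbers stand for slow clearance and higher numbers for fast clearance), compound 1 `NC(=O)c1ccc(Oc2ccc3c(c2)CCN(C2CCC2)CC3)nc1` gives < 3 mL.min-1.g-1 as a limit of the assay and not a number. Compound 2 `O=C(c1ccc(Oc2ccc3c(c2)CCN(C2CCC2)CC3)nc1)N1CCCC1` gives < 3 mL.min-1.g-1 which is likewise a limit and not a number. Within the data shown here, all that is known of the series so far is the limit of < 3 mL.min-1.g-1 in this assay, at which 2 of the 2 values shown sit, and no numerical clearance is available for either compound. Among the measured compounds shown here, the only measured step is a step that the two limits leave unreadable from compound 1 to compound 2 and it also changes the group on the carbonyl carbon. Compound 3 `CCN(C)C(=O)c1ccc(Oc2ccc3c(c2)CCN(C2CCC2)CC3)nc1` differs from compound 2 by ethyl(methyl)amino in place of pyrrolidin-1-yl on a carbonyl carbon with ethyl(methyl)amino in place of pyrrolidin-1-yl on a carbonyl carbon. For the measured compounds named here, with a step that the two limits leave unreadable from compound 1 to compound 2 as the sole precedent, no step beyond the scatter is expected in this assay and no direction can be assigned. The expected change is a step that the limit leaves unreadable from compound 2 to compound 3 as estimated here. Compound 3 is expected at 2.5 mL.min-1.g-1 with an estimated range of 1.5 mL.min-1.g-1 to 6 mL.min-1.g-1 in this assay.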

Compound 3, intrinsic clearance in microsomes: < 3 mL.min-1.g-1
Compound 3: a limit, no number; the forecaster's own chance of this, stated with the estimate: 65%; the middle value is on the limit's open side.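

Compound 1, compound 2 and compound 3 each give a limit and not a number in this assay, so no step among them can be read: the limit of < 3 mL.min-1.g-1 in this assay, at which 3 of the 3 values shown sit.

The compounds shown leave open whether amino, pyrrolidin-1-yl and ethyl(methyl)amino on the carbonyl carbon differ at all in clearance.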